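Compound 4: carbonyl in place of sulfonyl on the chain nitrogen

This account rests on a few compounds, and the source may have more. Where it says the series, first, only, none or still open, it means among the compounds named here.

Values in a functional assay on A-375 cells (Homo sapiens) for cytotoxicity, read by MTT assay; a lower number here means a stronger inhibitor, a higher number a weaker inhibitor:
compound 1 `COc1ccc(S(=O)(=O)NCCCNc2nccc(-c3c(-c4cccc(F)c4)nc4sccn34)n2)cc1`: 5510 nM
compound 2 `O=S(=O)(NCCCNc1nccc(-c2c(-c3cccc(F)c3)nc3sccn23)n1)c1ccc(C(F)(F)F)cc1`: 4090 nM
compound 3 `O=S(=O)(NCCNc1nccc(-c2c(-c3cccc(F)c3)nc3sccn23)n1)c1ccc(C(F)(F)F)cc1`: 7440 nM

Compound 1 stands second highest of the three numbers; compound 2 and compound 3 both lie within the scatter of it. Compound 4 `O=C(NCCCNc1nccc(-c2c(-c3cccc(F)c3)nc3sccn23)n1)c1ccc(Cl)cc1` differs from compound 1 in one place: (4-chlorophenyl)carbonyl in place of (4-methoxyphenyl)sulfonyl on an amine nitrogen. Among the measured compounds shown here, no measured step alters this part of the molecule. For the measured compounds named here, the only step on the same aryl group, a 1.3-fold lower number from compound 1 to compound 2 (0.13 log units; within the scatter), stayed within the scatter. Compound 2 and compound 3 differ only in chain length and give values within the scatter of each other. Going by the values given here, with no counterpart for the sulfonyl-to-carbonyl exchange, no step beyond the scatter is expected, and the range is kept wide. For compound 4 the expected value is 5000 nM (range 1500 nM to 16000 nM). The expected step is a 1.1-fold lower number from compound 1 to compound 4 (0.04 log units; within the scatter).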

Compound 4, half-maximal inhibitory concentration: 13700 nM
Beside the measured number, compound 4's estimate is 2.7-fold (0.44 log units) below it; the measured number falls inside the stated range.
By their numbers in this assay, from the lowest: compounds 2, 1, 3 and 4 (each within the scatter of the next, the first and the last beyond it).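

In this assay, the exchange on the amine nitrogen gives a step beyond the scatter, a 2.5-fold higher number from compound 1 to compound 4 (0.40 log units; beyond the scatter), whereas the aryl exchange alone, a 1.3-fold lower number from compound 1 to compound 2 (0.13 log units; within the scatter), stayed within it. This position therefore tolerates (4-chlorophenyl)carbonyl less well than (4-methoxyphenyl)sulfonyl, though the step is modest. Nothing measured here accounts for the step.

Sulfonyl and methoxy leave together, so the share of each in the step remains unresolved. Going by these compounds, a (4-methoxyphenyl)carbonyl group on the same nitrogen would separate the two, and a longer chain remains open.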